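Ethyl to methyl on the benzamide thioether

The source may hold more compounds than are shown below. What is called first, only, known or untested is meant among the compounds shown, and "the series" means these compounds.

Measured in a functional assay on SMMC-7721 cells (Homo sapiens) for inhibition, read by CCK-8 assay, with a stated time of 72 h, tested at 8 uM; on this read-out higher numbers stand for more inhibition of growth at the one concentration tested and lower numbers for less inhibition of growth:
- compound 1 `Nc1ccccc1NC(=O)/C=C/c1ccc(CSc2ccc(Cl)cc2)cc1`: 16.5%
- compound 2 `CCc1ccc(SCc2ccc(C(=O)Nc3ccccc3N)cc2)cc1`: 82.9%
- compound 3 `Nc1ccccc1NC(=O)/C=C/c1ccc(CSc2ccc(C(F)(F)F)cn2)cc1`: 20.1%

Compound 2 holds the highest of the three numbers, and the gaps down to compound 3 and compound 1 both lie beyond the scatter. The next compound to test is compound 4 `Cc1ccc(SCc2ccc(C(=O)Nc3ccccc3N)cc2)cc1`. Its difference from compound 2 is hydrogen in place of methyl on a saturated chain carbon bound to an aromatic carbon, which reads as 4-ethylphenyl to 4-methylphenyl.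

Within the data shown here, no measured step covers this change. The only one available, a number 3.6 percentage points higher from compound 1 to compound 3 (within the scatter), replaces a whole group on the sulfur and stays within the scatter. It offers only weak support for a small effect from changing that part of the molecule. Among the measured compounds shown here, compound 1 and compound 3 differ from compound 2 in more than one place, so their low values set no size for this step.

The expected result is a number 4.9 percentage points lower from compound 2 to compound 4 (within the scatter), with no shift beyond the scatter anticipated. The estimate for compound 4 is 78%, with an expected range from 58% to 92%.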

Compound 4, percent growth inhibition at one concentration: 82.7%
Estimate against measurement, compound 4: 4.7 percentage points below; measured number inside the range.
By their numbers in this assay, from the lowest: compounds 1 and 3 (each within the scatter of the next); then compounds 4 and 2 (each within the scatter of the next).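

In this assay, among these compounds, the change from 4-ethylphenyl to 4-methylphenyl gives a number 0.2 percentage points lower from compound 2 to compound 4 (within the scatter), the first measured step at this place, on a saturated chain carbon bound to an aromatic carbon. At the one concentration tested, the read-out therefore does not separate ethyl from methyl here, and losing this one carbon does not remove the high growth inhibition seen with compound 2. No available measurement offers a reason for this result.

Still open, as far as these compounds go, is whether this place also accepts a longer chain such as propyl, or an amine or a carboxylic acid, and whether compound 2 and compound 4 would separate at other concentrations. Compound 1 and compound 3 differ from compound 2 and compound 4 in more than one place, so which difference accounts for the gap between the two pairs also remains unresolved.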